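Working notes on four compounds in one mouse screen

The compounds below may be only part of what the source reports. "The series", "measured", "known", "first", "only" and "open" are said of these compounds alone.

Compound 1, `Cn1c(-c2ccccc2)nnc1[S+](C)[O-]`: in a functional assay on the whole organism for antagonist activity, with Mus musculus as the target, in the maximal electroshock model (a lower number here means that less compound is needed, a higher number that more compound is needed for the effect), compound 1 gives > 100 mg/kg, a limit of the assay and not a number.
Compound 2, `CC[S+]([O-])c1nnc(-c2ccccc2)n1C`: in this assay compound 2 gives > 200 mg/kg, again a limit.
Compound 3, `Cn1c(-c2ccccc2F)nnc1S(C)(=O)=O`: in this assay compound 3 gives > 100 mg/kg, also a limit.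

Compound 2 differs from compound 1 by methyl in place of hydrogen on a saturated chain carbon bound to a sulfur, and the step that the two limits leave unreadable from compound 1 to compound 2. What the two values show is the limit of > 100 mg/kg in this assay, at which 2 of the 3 values shown sit, and (the limit of > 200 mg/kg in this assay, at which 1 of the 3 values shown sits); nothing more can be read from them. Compound 3 differs from compound 1 in its core, and that difference is not broken down here.

Compound 4, `CCS(=O)(=O)c1nnc(-c2ccccc2F)n1C`, is not yet measured. It differs from compound 3 by methyl in place of hydrogen on a saturated chain carbon bound to a sulfonyl sulfur. This is the same kind of change as between compound 1 and compound 2, but the place reads "bound to a sulfonyl sulfur" rather than "bound to a sulfur".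

The expected step is a step that the limit leaves unreadable from compound 3 to compound 4. This estimate rests on compound 3 sitting at a limit, > 100 mg/kg, with the earlier step unreadable. Compound 4 is expected to give about 150 mg/kg, most likely again only a limit, within 50 mg/kg to 400 mg/kg.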

Compound 4, dose for half-maximal effect: > 200 mg/kg
Compound 4 ended at the assay's limit; the forecaster's own chance of this, stated with the estimate: 80%; middle value at least 1.3-fold (0.12 log units) away from the limit.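

Compound 3 and compound 4 both stand at limits of this assay, not at numbers, so the change from methylsulfonyl to ethylsulfonyl gives no readable step. The compounds shown leave open what dose, if any, gives a half-maximal effect for either compound.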